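Imidazole for benzimidazole on two chain-length cores

This account rests on a few compounds, and the source may have more. Where it says the series, first, only, none or still open, it means among the compounds named here.

The measured compounds and their values:
Compound 1, `COc1ccccc1N1CCN(CCCCn2nc(-n3cnc4ccccc43)ccc2=O)CC1`, 1.1 nM
Compound 2, `COc1ccccc1N1CCN(CCCCCCn2nc(-n3cnc4ccccc43)ccc2=O)CC1`, 6.4 nM
Compound 3, `COc1ccccc1N1CCN(CCCCn2nc(-n3ccnc3)ccc2=O)CC1`, 47.5 nM

Three compounds have been run in an assay on cell membranes from brain for binding affinity to Adrenergic receptor alpha-1 (Rattus norvegicus), read by radioligand binding; a higher number here means a weaker inhibitor, a lower number a stronger inhibitor. Compound 1 gives 1.1 nM and is the lowest number of the three. The core of compound 2 differs from that of compound 1, and the difference between the two cores is not broken down here. In this assay compound 2 gives 6.4 nM. Compound 3 gives 47.5 nM, the highest number of the set.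

Compound 3 arises from compound 1 by the change (1H-imidazol-1-yl in place of 1H-benzimidazol-1-yl on an aromatic carbon), and the step it made is a 43-fold higher number from compound 1 to compound 3 (1.64 log units; beyond the scatter).

Compound 4, `COc1ccccc1N1CCN(CCCCCCn2nc(-n3ccnc3)ccc2=O)CC1`, is not yet measured. It arises from compound 2 by the change (1H-imidazol-1-yl in place of 1H-benzimidazol-1-yl on an aromatic carbon), the same change as that from compound 1 to compound 3, at the same place in both descriptions. Compound 4 is expected to give an estimated 220 nM in this assay, with a likely range from 60 nM to 800 nM. Among the compounds with values here, that expectation rests on compound 2 at 6.4 nM and on the single earlier instance of the change, because a 43-fold higher number from compound 1 to compound 3 (1.64 log units; beyond the scatter) was large and beyond the scatter. Within the data shown here, the expected step is a 34-fold higher number from compound 2 to compound 4 (1.54 log units; beyond the scatter), estimated to be of similar size to the earlier one, with only one prior example to rest on.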

Compound 4, inhibition constant: 52.5 nM
Beside the measured number, compound 4's estimate is 4.2-fold (0.62 log units) above it, and the stated range ends above it.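

Putting 1H-imidazol-1-yl in place of 1H-benzimidazol-1-yl on the core of compound 2 again gave a higher number in this assay, with an 8.2-fold higher number from compound 2 to compound 4 (0.91 log units; beyond the scatter), so compound 4 moved in the same direction as the earlier instance of the change. This shows that the direction of the change carried from one core to the other in these two pairs, but that its size did not, and that the two steps cannot be treated as one fixed increment: the same change on two cores in this assay, a 43-fold higher number (1.64 log units; beyond the scatter) from compound 1 to compound 3 and an 8.2-fold higher number (0.91 log units; beyond the scatter) from compound 2 to compound 4, 5.3-fold (0.72 log units) apart, beyond the scatter of two such steps. Within the data shown here, it does not show why the size differs, and with only two cores it gives no rule for how large the step would be on a third, so the loss on the core of compound 2 cannot be taken as a general figure for the series.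

The compounds shown leave open whether the step would fall in size, rise again or change direction on a core carrying a pentylene or an octylene chain. They also leave open how other groups on the same aromatic carbon, such as 1H-indol-1-yl or 1H-benzotriazol-1-yl, would compare with the two groups tested here on either core.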